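The source may report more compounds than this note shows. Statements on the series, on what has been measured and on what is new or still open speak of the compounds shown alone.

Compound 1 `C[C@@]1(O)CC(=O)OC(CSc2nc(-c3ccccc3)c(-c3ccccc3)[nH]2)C1` has the lower of the two numbers measured in an assay on microsomes from liver for inhibition of sterol O-acyltransferase 1 (Rattus norvegicus) (a lower number here means a stronger inhibitor, a higher number a weaker inhibitor), where compound 1 gives 170 nM; compound 2 `COc1ccc(-c2nc(SCC3C[C@@](C)(O)CC(=O)O3)[nH]c2-c2ccc(OC)cc2)cc1` gives 340 nM in this assay, a gap within the scatter. Compound 3 `c1ccc(-c2nc(SCCC3OCCCO3)[nH]c2-c2ccccc2)cc1` awaits measurement. It differs from compound 1 in one place: a group of 7 heavy atoms (5 carbon, 2 oxygen; one six-membered non-aromatic ring with 2 hetero atoms) in place of a group of 9 heavy atoms (6 carbon, 3 oxygen; one six-membered non-aromatic ring with 1 hetero atom), on a saturated chain carbon bound to a sulfur. Among the measured compounds shown here, no step between measured compounds is available, so the size of this change is a judgement; since the group that leaves is the one counted with a hydrogen-bond donor, a modest weakening in this assay seems more likely than none. Compound 3 is therefore expected to give 500 nM, plausibly between 150 nM and 2000 nM, an expected step of a 2.9-fold higher number from compound 1 to compound 3 (0.47 log units; beyond the scatter).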

Compound 3, half-maximal inhibitory concentration: 730 nM
The estimate for compound 3 lay 1.5-fold (0.16 log units) below the measured number, within the range that was stated.
By their numbers in this assay, from the lowest: compounds 1 and 2 (each within the scatter of the next); then compound 3.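

At the saturated chain carbon bound to a sulfur, the exchange of groups gives a 4.3-fold higher number from compound 1 to compound 3 (0.63 log units; beyond the scatter) in this assay and lies beyond the scatter, so the number at this place does depend on the group it carries. The entering ring differs from the leaving one at once in hetero atoms, hydrogen-bond donors, the outside double bond and the defined stereocentre, and this single step cannot separate these differences. Nothing measured here accounts for the step. On these data alone, whether a plain hydroxyl group on the chain would bring the number back towards that of compound 1 stays open. So does the effect of an amine or a carboxylic acid at this place.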